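The source may report more compounds than this note shows. Statements on the series, on what has been measured and on what is new or still open speak of the compounds shown alone.

For the measured compounds named here, compound 1 `Cc1c(C)c2c(c(C)c1N)CC(C)(CN1CCN(c3ccccc3)CC1)O2` is the only compound in this small set with a numerical result: in a functional assay on the whole organism with Mus musculus as the target (a higher number here means that more compound is needed for the effect, a lower number that less compound is needed), compound 1 gives 13.1 mg/kg. Compound 2 `Cc1c(C)c2c(c(C)c1NC=O)CC(C)(C)O2` carries a formyl group on the ring nitrogen instead of the piperazinylmethyl side chain, and for compound 2 this assay reports only a limit, > 100 mg/kg, and not a number. As far as these compounds go, compound 2 thus stands at the limit of > 100 mg/kg in this assay, at which 1 of the 2 values shown sits, so its true position above that mark is unknown.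

Compound 3 `Cc1c(C)c2c(c(C)c1Nc1ccc(Cl)cc1)CC(C)(C)O2` is the next compound to be measured. It differs from compound 2 by 4-chlorophenyl in place of formyl on a nitrogen on an aromatic ring. Going by the values given here, no step between two numerically measured compounds is recorded, so the size of the step from compound 2 to compound 3 in this assay can only be expected, not derived: the expected direction is toward a lower dose, by a margin beyond the scatter, though with a real chance that only a limit is returned again.

Compound 3 is estimated to give 40 mg/kg, with a range from 10 mg/kg to 150 mg/kg, which corresponds to an expected step of an at least 2.5-fold lower number from compound 2 to compound 3 (0.39 log units; beyond the scatter).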

Compound 3, dose for 50% inhibition: > 50 mg/kg
Compound 3 was reported as a limit; the forecaster's own chance of this, stated with the estimate: 35%; middle value at least 1.2-fold (0.09 log units) from the limit.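

In this assay, for the compounds shown here, compound 2 and compound 3 each return only a limit, and no step between them can be read. The compounds shown leave open where either truly stands, and whether 4-chlorophenyl in place of formyl changes the dose needed at all.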